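The source may hold more compounds than are shown below. What is called first, only, known or untested is meant among the compounds shown, and "the series" means these compounds.

Compound 1 `Oc1ccc(-c2cc(-c3ccccn3)cc(-c3ccc(O)cc3)n2)cc1` gives 1040 nM in a functional assay on T47D cells (Homo sapiens) for cytotoxicity, read by CCK-8 assay; on this read-out lower numbers stand for stronger inhibition and higher numbers for weaker inhibition. Compound 2 `Oc1ccc(-c2cc(-c3cccnc3)cc(-c3ccccc3O)n2)cc1` reaches only the assay limit, > 50000 nM. Compound 3 `Oc1ccc(-c2cc(-c3cccnc3)cc(-c3cccc(O)c3)n2)cc1` likewise stops at the limit, > 50000 nM. The step that the two limits leave unreadable from compound 2 to compound 3 therefore cannot be sized; both sit at the limit of > 50000 nM in this assay, at which 2 of the 3 values shown sit. Compound 3 thus stands at the weak end of what this assay can report, with one other limit beside it. Compound 4 `Oc1ccc(-c2cc(-c3cccnc3)cc(-c3ccc(O)cc3)n2)cc1` differs from compound 3 by 4-hydroxyphenyl in place of 3-hydroxyphenyl on an aromatic carbon. For the measured compounds named here, no measured step covers this change, since the only measured step runs between two limits. Compound 1, which also carries 4-hydroxyphenyl groups, sits inside the readable range at 1040 nM, so compound 4 is expected to move toward that value by an at least 10-fold lower number from compound 3 to compound 4 (1.00 log units; beyond the scatter). The estimate for compound 4 is 5000 nM, between 800 nM and 50000 nM.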

Compound 4, half-maximal inhibitory concentration: 2030 nM
For compound 4 the middle estimate is 2.5-fold (0.39 log units) above the measured one; measured number inside the range.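

With the pyridin-3-yl group kept, only 4-hydroxyphenyl gives a readable value in this assay, with an at least 24-fold lower number from compound 3 to compound 4 (1.39 log units; beyond the scatter) and an at least 24-fold lower number from compound 2 to compound 4 (1.39 log units; beyond the scatter). Both steps are minimum sizes, set by a limit: the limit of > 50000 nM in this assay, at which 2 of the 4 values shown sit.

Exchanging pyridin-2-yl for pyridin-3-yl gives a 2.0-fold higher number from compound 1 to compound 4 (0.29 log units; within the scatter), so these two groups cannot be told apart when 4-hydroxyphenyl is present.

As far as these compounds go, it remains open whether the hydroxyl itself matters or only the place it occupies; a 4-methoxyphenyl or 4-aminophenyl group in place of 4-hydroxyphenyl would test this. A pyridin-4-yl group in place of pyridin-3-yl also remains untested among the compounds shown.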